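Swapping the fluorinated ring for a methyl-bearing ring

The compounds below may be only part of what the source reports. "The series", "measured", "known", "first", "only" and "open" are said of these compounds alone.

In a functional assay on M21 cells (Homo sapiens) for antiproliferative activity, read by sulforhodamine B assay, with a stated time of 48 h (on this read-out higher numbers stand for weaker inhibition and lower numbers for stronger inhibition), compound 3 `O=C1NCCN1c1ccc(S(=O)(=O)Nc2ccc(F)c(F)c2)cc1` gives 220 nM, the highest of the two numbers that were read. The nearest is compound 1 `Cc1ccc(NS(=O)(=O)c2ccc(N3CCNC3=O)cc2)cc1C`, which in this assay gives 94 nM. For compound 2 `CCCCCCCc1ccc(NS(=O)(=O)c2ccc(N3CCNC3=O)cc2)cc1` this assay reports only a limit, > 1000 nM, not a number. Compound 4 `Cc1ccccc1NS(=O)(=O)c1ccc(N2CCNC2=O)cc1` differs from compound 3 at one place: 2-methylphenyl in place of 3,4-difluorophenyl on a sulfonamide nitrogen. Among the measured compounds shown here, the one measured step that bears on this is the change a 2.3-fold higher number from compound 1 to compound 3 (0.37 log units; beyond the scatter), which moved the number upward. Compound 4 returns to a methyl-bearing ring, so a step of similar size in the opposite direction is expected, a 1.8-fold lower number from compound 3 to compound 4 (0.26 log units; within the scatter). For compound 4 the value is therefore estimated at 120 nM, within 50 nM to 400 nM.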

Compound 4, half-maximal inhibitory concentration: 150 nM
Estimate against measurement, compound 4: 1.3-fold (0.10 log units) below; the measured number falls inside the stated range.
By their numbers in this assay, from the lowest: compounds 1, 4 and 3 (each within the scatter of the next, the first and the last beyond it). At a limit, above all of these: compound 2.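

On the sulfonamide nitrogen, 2-methylphenyl cannot be told apart from either earlier ring, with a 1.5-fold lower number from compound 3 to compound 4 (0.17 log units; within the scatter) and a 1.6-fold higher number from compound 1 to compound 4 (0.20 log units; within the scatter) as the two steps. Compound 4 carries neither fluorine nor a second methyl, yet it stays within the scatter of both compound 1 and compound 3, although those two differ by more than the scatter. This position therefore holds its number without either feature of the earlier rings.

Going by these compounds, whether a plain phenyl, a methoxy-bearing ring or a nitrile-bearing ring would read the same stays open. Nothing given here explains why these three rings read so alike.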